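A few compounds are considered here, and "the series" means these few. Any claim that something is new, unique, unknown or untested is made for them only; others in the source may bear on it.

The series shares one core, seen in compound 1 `O=S(=O)(c1cc(F)cc(F)c1)c1cnc2cc(F)ccc2c1-c1ccc(Cl)cc1`, compound 2 `COc1ccc(S(=O)(=O)c2cnc3cc(F)ccc3c2-c2ccc(Cl)cc2)cc1` and compound 3 `O=S(=O)(c1cccc(F)c1)c1cnc2cc(F)ccc2c1-c1ccc(Cl)cc1`. In an ADME assay on microsomes from liver (Homo sapiens) for metabolic stability, tested at 2.5 uM (a higher number here means faster removal of the compound, a lower number slower removal), compound 1 gives 0.03 mL/min, compound 2 gives 1.28 mL/min and compound 3 gives 0.98 mL/min. On these numbers compound 3 stands second highest of the three: its nearest neighbour is compound 2, where a 1.3-fold lower number from compound 2 to compound 3 (0.12 log units; within the scatter), and its furthest is compound 1, where a 33-fold higher number from compound 1 to compound 3 (1.51 log units; beyond the scatter). Compound 4 `Cc1ccc(S(=O)(=O)c2cnc3cc(F)ccc3c2-c2ccc(Cl)cc2)cc1C` differs from compound 3 by 3,4-dimethylphenyl in place of 3-fluorophenyl on a sulfonyl sulfur. Two earlier changes at the same sulfonyl sulfur bear on this step: a 43-fold higher number from compound 1 to compound 2 (1.63 log units; beyond the scatter), and a 1.3-fold lower number from compound 2 to compound 3 (0.12 log units; within the scatter). Because a 1.3-fold lower number from compound 2 to compound 3 (0.12 log units; within the scatter), compound 4 is expected to show a 1.5-fold higher number from compound 3 to compound 4 (0.18 log units; within the scatter) in this assay. Compound 4 is therefore estimated at 1.5 mL/min, with a range from 0.6 mL/min to 4 mL/min.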

Compound 4, intrinsic clearance in a liver preparation (reported as CLH), per the amount of preparation that the assay uses: 7.88 mL/min
The estimate for compound 4 lay 5.3-fold (0.72 log units) below the measured number; measured number outside the range, above it.
By their numbers in this assay, from the lowest: compound 1; then compounds 3 and 2 (each within the scatter of the next); then compound 4.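

At the sulfonyl sulfur, 3,4-dimethylphenyl gives the highest number of the four compounds in this assay, with an 8.0-fold higher number from compound 3 to compound 4 (0.91 log units; beyond the scatter), a 6.2-fold higher number from compound 2 to compound 4 (0.79 log units; beyond the scatter) and a 260-fold higher number from compound 1 to compound 4 (2.42 log units; beyond the scatter). The earlier compounds shown here showed one wide gap, set by 3,5-difluorophenyl; this result shows that groups other than 3,5-difluorophenyl at this position can also differ beyond the scatter. Nothing given here explains this rise. The compounds shown leave open whether a single methyl group would give a similar number, and how an amine or a carboxylic acid on this phenyl ring would behave.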